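Swapping the aryl group on the triazole of compound 3

A few compounds are considered here, and "the series" means these few. Any claim that something is new, unique, unknown or untested is made for them only; others in the source may bear on it.

Three compounds built on the same triterpenoid-like core were tested in a functional assay on HepG2 cells (Homo sapiens) for cytotoxicity, read by MTT assay, with a stated time of 48 h; on this read-out lower numbers stand for stronger inhibition and higher numbers for weaker inhibition. Compound 1 `CC(C)=CCC/C(C)=C/CC/C(C)=C/CC[C@@H]1[C@@]2(C)CC/C(=N\OCc3cn(-c4cccc(C(F)(F)F)c4)nn3)C(C)(C)[C@@H]2CC[C@@]1(C)O` gives 22700 nM. Compound 2 `CC(C)=CCC/C(C)=C/CC/C(C)=C/CC[C@@H]1[C@@]2(C)CC/C(=N\OCc3cn(-c4ccc(F)c(F)c4F)nn3)C(C)(C)[C@@H]2CC[C@@]1(C)O` gives 37700 nM. Compound 3 `COc1cccc(-n2cc(COc3ccc(/C=C4\C[C@]5(C)[C@@H](CC/C=C(\C)CC/C=C(\C)CCC=C(C)C)[C@](C)(O)CC[C@H]5C(C)(C)C4=O)cc3)nn2)c1` gives 50100 nM. Among these three, compound 3 sits at the high end: its gap to compound 2 lies within the usual scatter, whereas compound 1 sits lower by a margin beyond it.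

Compound 4 `CC(C)=CCC/C(C)=C/CC/C(C)=C/CC[C@@H]1[C@@]2(C)C/C(=C\c3ccc(OCc4cn(-c5ccncc5)nn4)cc3)C(=O)C(C)(C)[C@@H]2CC[C@@]1(C)O` has not yet been measured. It differs from compound 3 in one place: pyridin-4-yl in place of 3-methoxyphenyl on an aromatic nitrogen. For the measured compounds named here, the one measured step that resembles this change is the swap of one aromatic group for another on the same aromatic nitrogen, going a 1.7-fold higher number from compound 1 to compound 2 (0.22 log units; within the scatter). That step stayed within the scatter, so a comparable aryl swap here is expected to shift the number little, in no clear direction. The number for compound 4 in this assay is therefore estimated at 45000 nM, within a range from 20000 nM to 100000 nM, which corresponds to an expected step of a 1.1-fold lower number from compound 3 to compound 4 (0.05 log units; within the scatter).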

Compound 4, half-maximal inhibitory concentration: 105000 nM
The estimate for compound 4 lay 2.3-fold (0.37 log units) below the measured number; measured number outside the range, above it.
By their numbers in this assay, from the lowest: compounds 1, 2 and 3 (each within the scatter of the next, the first and the last beyond it); then compound 4.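

The aryl group on this aromatic nitrogen can matter: in this assay, pyridin-4-yl in place of 3-methoxyphenyl gives a 2.1-fold higher number from compound 3 to compound 4 (0.32 log units; beyond the scatter) and this modest step lies beyond the scatter. The earlier aryl swap, a 1.7-fold higher number from compound 1 to compound 2 (0.22 log units; within the scatter) and within the scatter, gave no such sign. Here, a ring with a hetero atom in place of a carbon-only ring goes with weaker inhibition on this read-out, although this rests on a single pair, and no measurement at hand explains the step.

This one change both removes the methoxy group and puts a nitrogen into the ring, so the two cannot be separated here. From the compounds shown here alone, an unsubstituted phenyl or a pyridin-3-yl group at this position would help to separate them, and whether the same swap behaves alike on the core of compound 1 remains open.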